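Working notes: from compound 1 to compound 4

The source may hold more compounds than are shown below. What is called first, only, known or untested is meant among the compounds shown, and "the series" means these compounds.

Measured in a functional assay on HepG2 cells (Homo sapiens) for cytotoxicity, read by MTT assay, with a stated time of 72 h; on this read-out lower numbers stand for stronger inhibition and higher numbers for weaker inhibition:
compound 1 `O=C1C=CCC/C1=C\C=C\c1ccccc1`: 7100 nM
compound 2 `CC(=C\c1ccccc1)/C=C1\CCC=CC1=O`: 4600 nM
compound 3 `O=C1C=CCC/C1=C\C=C\c1ccc(Br)cc1`: 6100 nM

Compound 1 has the highest of the three numbers, yet both neighbours sit within the scatter of it: a 1.2-fold lower number from compound 1 to compound 3 (0.07 log units; within the scatter) and a 1.5-fold lower number from compound 1 to compound 2 (0.19 log units; within the scatter). Going by the values given here, no compound can therefore be called stronger or weaker than another here.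

The next step is to compound 4 `CN(C)c1ccc(/C=C/C=C2\CCC=CC2=O)cc1`, with dimethylamino in place of hydrogen on an aromatic carbon. The step from compound 1 to compound 3 bears most directly, as it also replaces hydrogen on an aromatic carbon, and it stayed within the scatter; the chain change to compound 2 did likewise. Nothing measured speaks for dimethylamino in particular. The expectation in this assay is thus no step beyond the scatter, a 1.3-fold lower number from compound 1 to compound 4 (0.11 log units; within the scatter). For compound 4 the estimate is 5500 nM, from 2500 nM to 13000 nM.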

Compound 4, half-maximal inhibitory concentration: 1100 nM
Beside the measured number, compound 4's estimate is 5.0-fold (0.70 log units) above it; measured number outside the range, below it.
By their numbers in this assay, from the lowest: compound 4; then compounds 2, 3 and 1 (each within the scatter of the next).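

In this assay, this aromatic carbon, para to a large group, proves responsive to substitution: dimethylamino gives a 6.5-fold lower number from compound 1 to compound 4 (0.81 log units; beyond the scatter), while bromo at the same carbon stayed within the scatter. Exchanging one group for the other gives a 5.5-fold lower number from compound 3 to compound 4 (0.74 log units; beyond the scatter), so the outcome at this position depends on the group it carries. Nothing on hand accounts for this difference between the two groups.

As far as these compounds go, whether the lower number is particular to dimethylamino or extends to other groups here, such as methoxy or a primary amine, remains open. Also open, from the compounds shown here alone, is whether dimethylamino and the chain methyl of compound 2 would combine.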